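From a Thiophene Ketone to a Dimethoxyphenyl Ketone

The source may report more compounds than this note shows. Statements on the series, on what has been measured and on what is new or still open speak of the compounds shown alone.

Measured compounds:
compound 1 `O=C(/C=C/c1cn(-c2ccccc2)nc1-c1cccnc1)c1ccsc1`: 1300 nM
compound 2 `O=C(/C=C/c1cn(-c2ccccc2)nc1-c1ccncc1)c1ccsc1`: 1100 nM

In a functional assay on HCT-116 cells (Homo sapiens) for inhibition, read by sulforhodamine B assay, with a stated time of 72 h (on this read-out lower numbers stand for stronger inhibition and higher numbers for weaker inhibition), compound 1 gives 1300 nM and compound 2 gives 1100 nM. Going by the values given here, the single measured step, a 1.2-fold lower number from compound 1 to compound 2 (0.07 log units; within the scatter), lies within the scatter, so compound 2 stands level with compound 1 on these two numbers. Compound 3 `COc1ccc(OC)c(C(=O)/C=C/c2cn(-c3ccccc3)nc2-c2ccncc2)c1` differs from compound 2 by 2,5-dimethoxyphenyl in place of thiophen-3-yl on a carbonyl carbon. Among the compounds with values here, no measured step touches the group on the carbonyl carbon; the only measured step concerns the pyridyl ring. Compound 3 is therefore estimated with a wide range, at 700 nM (150 nM to 3000 nM) in this assay. That estimate means an expected step of a 1.6-fold lower number from compound 2 to compound 3 (0.20 log units; within the scatter).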

Compound 3, half-maximal inhibitory concentration: 900 nM
Compound 3: the middle estimate sits 1.3-fold (0.11 log units) below what was measured, and the stated range covers the measured number.
By their numbers in this assay, from the lowest: compounds 3, 2 and 1 (each within the scatter of the next).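

Moving to the 2,5-dimethoxyphenyl group on the carbonyl carbon gives a 1.2-fold lower number from compound 2 to compound 3 (0.09 log units; within the scatter) in this assay. Going by these compounds alone, this is the first measured change at this position, and it shows that a six-membered aromatic ring of carbon only, with 10 heavy atoms, stands level with the 5-atom thiophen-3-yl group. No evidence is available on why the two groups stand level. The compounds shown leave open whether a single methoxy group would stand level as well. They also leave open whether an amine or a carboxylic acid on the phenyl ring would move the number beyond the scatter.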